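A few compounds are considered here, and "the series" means these few. Any claim that something is new, unique, unknown or untested is made for them only; others in the source may bear on it.

Series notes, values in a physicochemical assay for lipophilicity, read by HPLC, using the shake flask method, measured as octanol-water partition, with a stated time of 24 h, at pH 7.4 (a higher number here means a more lipophilic compound, a lower number a more polar compound), so far:

compound 1 `COC(=O)Cn1c(=O)oc2c(C(=O)/C=C/c3ccc(O)cc3)cccc21` gives 1.46
compound 2 `COC(=O)Cn1c(=O)oc2c(C(=O)/C=C/c3cc(F)c(O)c(F)c3)cccc21` gives 1.07
compound 3 `COC(=O)Cn1c(=O)oc2c(C(=O)/C=C/c3ccc(O)c(O)c3)cccc21` gives 0.86

Compound 3 stands within the scatter of compound 2 (a number 0.21 log units lower from compound 2 to compound 3 (within the scatter)) and clearly under compound 1 (a number 0.60 log units lower from compound 1 to compound 3 (beyond the scatter)). Compound 4 `CC(C)=CCCn1c(=O)oc2c(C(=O)/C=C/c3ccc(O)c(O)c3)cccc21` carries 3-methylbut-2-en-1-yl in place of methoxycarbonyl on a saturated chain carbon bound to an aromatic nitrogen. Among the compounds with values here, no measured step touches this place. The nearest guide, a number 0.39 log units lower from compound 1 to compound 2 (beyond the scatter), is modest and changes only the hydroxyphenyl group, as does the step to compound 3. Within the data shown here, the entering group is all carbon and the leaving one is not, so a rise in this assay larger than these modest steps is expected, although no measured compound tests this. The expected size is a number 1.64 log units higher from compound 3 to compound 4 (beyond the scatter) (an estimate). Compound 4 is estimated at 2.5 (expected range 1.9 to 3.2).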

Compound 4, distribution coefficient: 1.04
The estimate for compound 4 lay 1.46 log units above the measured number; measured number below the stated range.
By their numbers in this assay, from the lowest: compounds 3, 4 and 2 (each within the scatter of the next); then compound 1.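

In this assay the exchange on a saturated chain carbon bound to an aromatic nitrogen gives a number 0.18 log units higher from compound 3 to compound 4 (within the scatter), the only step at this place among the compounds shown. At this place, with the 3,4-dihydroxyphenyl group held constant, the readings do not separate 3-methylbut-2-en-1-yl from methoxycarbonyl. No available evidence bears on this result.

On these data alone, whether a carboxylic acid or an amine at this place would stay within the scatter of compound 3 remains open. So does whether the same exchange would give a similar step with the 4-hydroxyphenyl group of compound 1.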